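Oxazoline for thiazoline on two cores: nitric oxide readout

The source may report more compounds than this note shows. Statements on the series, on what has been measured and on what is new or still open speak of the compounds shown alone.

Four compounds share the same side chain arrangement on a saturated chain carbon bound to a sulfonyl sulfur, differing in the five-membered ring at its end and in the core. Compound 1 `COc1ccc(C2=NN(c3ccccc3)C(c3ccc(C)cc3)C2S(=O)(=O)CC2=NCCO2)cc1` and compound 2 `COc1ccc(C2=NN(c3ccccc3)C(c3ccc(C)cc3)C2S(=O)(=O)CC2=NCCS2)cc1` carry the core of compound 1; compound 3 `COc1ccc(-c2noc(-c3ccc(C)cc3)c2S(=O)(=O)CC2=NCCS2)cc1` and compound 4 `COc1ccc(-c2noc(-c3ccc(C)cc3)c2S(=O)(=O)CC2=NCCO2)cc1` carry a second core. The difference between the two cores is not broken down here.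

In a functional assay, read by Griess assay, with a stated time of 150 min, tested at 50 ug/mL (a lower number here means a weaker effect, a higher number a stronger effect of the compound at the concentration tested), compound 1 gives 59.1% and compound 2 gives 39.4%. The change a group of 5 heavy atoms (3 carbon, 1 nitrogen, 1 oxygen; one five-membered non-aromatic ring with 2 hetero atoms) in place of a group of 5 heavy atoms (3 carbon, 1 nitrogen, 1 sulfur; one five-membered non-aromatic ring with 2 hetero atoms), on a saturated chain carbon bound to a sulfonyl sulfur produced a number 19.7 percentage points higher from compound 2 to compound 1 (beyond the scatter), so on the core of compound 1 the oxazoline end group is the more active of the pair. Compound 3 in this assay gives "not active" (no number reported), with no number given.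

Compound 4 is the same kind of change applied to the second core, (a group of 5 heavy atoms (3 carbon, 1 nitrogen, 1 oxygen; one five-membered non-aromatic ring with 2 hetero atoms) in place of a group of 5 heavy atoms (3 carbon, 1 nitrogen, 1 sulfur; one five-membered non-aromatic ring with 2 hetero atoms), on a saturated chain carbon bound to a sulfonyl sulfur), with the place worded identically in both pairs. Because compound 3 gives "not active" (no number reported) in this assay, and because the earlier step was only a number 19.7 percentage points higher from compound 2 to compound 1 (beyond the scatter) in size, the expectation for compound 4 is modest: a gain of roughly the same size as seen from compound 2 to compound 1, starting from a baseline near zero. Compound 4 is therefore estimated at 15% in this assay, with the expected range from 0% to 35%, and a fair chance that it too is reported only as not active.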

Compound 4, a percentage reported as activity, at one concentration (the size of the read-out at that concentration, not a potency): 68.8%
The estimate for compound 4 lay 53.8 percentage points below the measured number, outside the stated range (above it).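

No step can be read between compound 3 and compound 4: in this assay compound 3 gives "not active" (no number reported) and compound 4 gives 68.8%, which leaves one side of the pair without a number. The compounds shown leave open how large this end-group exchange is on the second core, and whether it matches the step on the core of compound 1. Nothing available here bears on the reason for this result.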